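Sulfanyl to benzylamino swap on the shared diamino core

A few compounds are considered here, and "the series" means these few. Any claim that something is new, unique, unknown or untested is made for them only; others in the source may bear on it.

For the measured compounds named here, compound 1 `Nc1cc(N)c2nc(-c3ccccc3)c(Sc3ccc(F)cc3)nc2c1` is the one member of the series with a plain number in a functional assay on SF-539 cells (Homo sapiens) for inhibition, read by sulforhodamine B assay, with a stated time of 48 h (a lower number here means that less compound is tolerated, a higher number that more compound is tolerated), where compound 1 gives 75900 nM. Compound 2 `CCOC(=O)[C@H](CCC(=O)O)NC(=O)c1ccc(Oc2nc3cc(N)cc(N)c3nc2-c2ccccc2)cc1` reaches only a limit in this assay, < 100000 nM, so that (the limit of < 100000 nM in this assay, at which 1 of the 2 values shown sits). Compound 3 `Nc1cc(N)c2nc(-c3ccccc3)c(NCc3ccc(F)cc3)nc2c1` is not yet measured; it differs from compound 1 by (4-fluorobenzyl)amino in place of (4-fluorophenyl)sulfanyl on an aromatic carbon. Going by the values given here, no step between two measured compounds is available, so the weight of this change is untested. The step from compound 1 to compound 3 is expected to stay within the scatter, with no clear direction, a 1.3-fold lower number from compound 1 to compound 3 (0.10 log units; within the scatter). Compound 3 is accordingly estimated at 60000 nM, within 20000 nM to 150000 nM.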

Compound 3, concentration lethal to 50% of the cells: 6920 nM
Estimate against measurement, compound 3: 8.7-fold (0.94 log units) above; the measured number lies below the stated range.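

For the compounds shown here, the aromatic carbon next to the ring nitrogen is sensitive to its substituent: in this assay, (4-fluorobenzyl)amino in place of (4-fluorophenyl)sulfanyl gives an 11-fold lower number from compound 1 to compound 3 (1.04 log units; beyond the scatter) and provides the first readable step. The swap exchanges sulfur for a nitrogen bearing a hydrogen-bond donor and also adds a carbon, so the step reflects these changes together. No measurement shown accounts for the step.

Which of these changes carries the step stays open. A (4-fluorophenyl)amino or (4-fluorobenzyl)sulfanyl group at this carbon would separate them.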